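Cyclohexyl for Chlorophenyl at the Branching Carbon

The compounds below may be only part of what the source reports. "The series", "measured", "known", "first", "only" and "open" are said of these compounds alone.

Compound 1 `CCc1cc(Nc2nc(N[C@@H](C)c3cccc(F)c3)nc3ccccc23)n[nH]1`: 340 nM
Compound 2 `CCc1cc(Nc2nc(N[C@@H](C)c3ccc(Cl)cc3)nc3ccccc23)n[nH]1`: 70 nM

In an assay on isolated protein for inhibition of G protein-coupled receptor kinase 6 (Homo sapiens), read by scintillation counting, radiometric assay and 33P incorporation, with a stated time of 80 min, in the presence of a further agent that is not named here (on this read-out higher numbers stand for weaker inhibition and lower numbers for stronger inhibition), compound 2 gives the lowest of the two numbers, and compound 1 sits above it by the step of a 4.9-fold lower number from compound 1 to compound 2 (0.69 log units; beyond the scatter). Compound 3 `CCc1cc(Nc2nc(N[C@@H](C)C3CCCCC3)nc3ccccc23)n[nH]1` differs from compound 2 by cyclohexyl in place of 4-chlorophenyl on a saturated chain carbon bound to a nitrogen on an aromatic ring and a saturated chain carbon. Within the data shown here, the one measured step compares two aromatic rings at this position and so bears only indirectly on an exchange of an aromatic ring for a saturated one; it does show that variation at this carbon can move the number beyond the scatter. Among the measured compounds shown here, no measured compound carries a saturated ring here, so the direction rests on that single step alone. Compound 3 is expected to give a somewhat higher number than its neighbour. The expected step is a 2.9-fold higher number from compound 2 to compound 3 (0.46 log units; beyond the scatter). The estimate for compound 3 in this assay is 200 nM, with a range from 50 nM to 800 nM.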

Compound 3, half-maximal inhibitory concentration: 960 nM
Compound 3: the middle estimate sits 4.8-fold (0.68 log units) below what was measured; the whole stated range lies below it.
By their numbers in this assay, from the lowest: compound 2; then compound 1; then compound 3.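

In this assay, a saturated ring at this carbon proves the least favourable of the three groups shown, with a 14-fold higher number from compound 2 to compound 3 (1.14 log units; beyond the scatter) and a 2.8-fold higher number from compound 1 to compound 3 (0.45 log units; beyond the scatter), so both halogenated aromatic rings give lower numbers than cyclohexyl. The size of the change depends on which aromatic ring is replaced, and the 4-chlorophenyl group of compound 2 has the most to lose. Each step, however, removes the halogen and the aromatic ring together, so the two changes cannot be told apart here, and no supporting information explains the loss.

On these data alone, whether an unsubstituted phenyl group would stay close to compound 2 or fall towards compound 3 remains open. Also open, as far as these compounds go, is how a piperidinyl ring, or a cyclohexyl ring carrying chlorine or an amine, would read at this carbon.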